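Nitro to Bromo on the Aromatic Carbon of Compound 3

This account rests on a few compounds, and the source may have more. Where it says the series, first, only, none or still open, it means among the compounds named here.

Measured compounds:
- compound 1 `CC(C)NC1CC(=O)N(c2ccc(F)c(Cl)c2)C1OCC(F)(F)F`: in a functional assay on MDA-MB-231 cells (Homo sapiens) for inhibition (a higher number here means a weaker inhibitor, a lower number a stronger inhibitor), compound 1 gives > 100000 nM, which is a limit of the assay and not a number.
- compound 2 `CCc1ccc(N2C(=O)C=CC2OCC(F)(F)F)cc1`: in this assay compound 2 gives 7840 nM.
- compound 3 `O=C1C=CC(OCC(F)(F)F)N1c1ccc([N+](=O)[O-])cc1`: in this assay compound 3 gives 2830 nM.

Among the two numbers, compound 3 stands lowest; its nearest neighbour is compound 2, and the step of a 2.8-fold lower number from compound 2 to compound 3 (0.44 log units; beyond the scatter) lies beyond the scatter. The third value, that of compound 1, sits at the limit of > 100000 nM in this assay, at which 1 of the 3 values shown sits, and says only that it is a limit.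

Compound 4 `O=C1C=CC(OCC(F)(F)F)N1c1ccc(Br)cc1` differs from compound 3 by bromo in place of nitro on an aromatic carbon. Among the compounds with values here, the only measured step that touches this carbon is a 2.8-fold lower number from compound 2 to compound 3 (0.44 log units; beyond the scatter), where nitro replaced ethyl and the number fell modestly. Compound 4 now removes that nitro again, but what enters is bromo, not ethyl, so the measured step offers only a loose guide. A modest move back toward the number of compound 2, or no change beyond the scatter, is the expected outcome.

Compound 4 is therefore estimated at 5000 nM, within 1500 nM to 15000 nM, which corresponds to the expected step of a 1.8-fold higher number from compound 3 to compound 4 (0.25 log units; within the scatter).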

Compound 4, half-maximal inhibitory concentration: 7570 nM
The estimate for compound 4 lay 1.5-fold (0.18 log units) below the measured number, and the stated range covers the measured number.
By their numbers in this assay, from the lowest: compound 3; then compounds 4 and 2 (each within the scatter of the next). At a limit, above all of these: compound 1.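

In this assay, putting bromo in place of nitro gives a 2.7-fold higher number from compound 3 to compound 4 (0.43 log units; beyond the scatter), so the earlier gain on this aromatic carbon, para to a large group, is lost with a group other than the ethyl it first replaced. Set against ethyl itself, bromo brings no readable difference: the step is a 1.0-fold lower number from compound 2 to compound 4 (0.02 log units; within the scatter), which means that two quite different substituents, one an alkyl chain and the other a single halogen atom, cannot be told apart here. Among the three groups seen on this carbon, nitro alone stands apart, with the lower number of compound 3 now resting on two steps beyond the scatter, a 2.8-fold lower number from compound 2 to compound 3 (0.44 log units; beyond the scatter) and the one to bromo, rather than on a single comparison.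

Nothing among the data at hand accounts for why nitro stands apart from ethyl and bromo. Going by these compounds, whether a nitrile, a carboxylic acid, an amine or a longer chain on this same carbon would side with nitro, or with ethyl and bromo, remains open.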